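This account rests on a few compounds, and the source may have more. Where it says the series, first, only, none or still open, it means among the compounds named here.

Compound 2 `Cc1ccc(-c2csc(N3N=C(c4ccc(Cl)s4)CC3c3ccc(F)cc3)n2)cc1` stands at a limit rather than a number in a functional assay on A549 cells (Homo sapiens) for antiproliferative activity, read by XTT assay, with a stated time of 24 h; on this read-out higher numbers stand for weaker inhibition and lower numbers for stronger inhibition: compound 2 gives > 500 ug/mL. Compound 1 `Fc1ccc(C2CC(c3ccc(Cl)s3)=NN2c2nc(-c3ccc(Cl)cc3)cs2)cc1` gives 125 ug/mL in this assay. Among the compounds with values here, the single measured step, an at least 4.0-fold higher number from compound 1 to compound 2 (0.60 log units; beyond the scatter), involved one value sitting at the limit of > 500 ug/mL in this assay, at which 1 of the 2 values shown sits. Compound 3 `O=[N+]([O-])c1ccc(-c2csc(N3N=C(c4ccc(Cl)s4)CC3c3ccc(F)cc3)n2)cc1` differs from compound 2 by nitro in place of methyl on an aromatic carbon. Within the data shown here, only that one step bears on this change, and it ran in the opposite direction, so the expectation rests on little. The expected step is an at least 2.5-fold lower number from compound 2 to compound 3 (0.39 log units; beyond the scatter), back toward the stronger side. Compound 3 is estimated at 200 ug/mL, within a range from 60 ug/mL to 600 ug/mL.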

Compound 3, half-maximal inhibitory concentration: > 500 ug/mL
Compound 3 was reported as a limit; the forecaster's own chance of this, stated with the estimate: 35%; middle value at least 2.5-fold (0.39 log units) away from the limit.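

Nitro at this place, para to a large group, gives no readable number in this assay, and the step between methyl and nitro cannot be read, as both values are limits. Replacing the chloro of compound 1 gives an at least 4.0-fold higher number from compound 1 to compound 3 (0.60 log units; beyond the scatter), so among the three compounds only chloro gives a value inside the measured range. Methyl and nitro, two quite different groups, end up at the same limit: the limit of > 500 ug/mL in this assay, at which 2 of the 3 values shown sit.

Going by these compounds, whether compound 2 and compound 3 differ at all past that limit stays open. So does whether a bromo, a methoxy or an amine at this place would behave like chloro.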